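A Larger Group at the Ring Position of Compound 3

A few compounds are considered here, and "the series" means these few. Any claim that something is new, unique, unknown or untested is made for them only; others in the source may bear on it.

Among the compounds with values here, compound 3 `O=c1c(-c2nn[nH]n2)c[nH]c2c(F)cccc12` gives 0.625 mg/kg in a functional assay on the whole organism (strain Sprague-Dawley) for inhibition, with Rattus norvegicus as the target (a lower number here means that less compound is needed, a higher number that more compound is needed for the effect), the second highest of the three numbers known. Compound 2 `O=c1c(-c2nn[nH]n2)c[nH]c2ccccc12` gives 1.25 mg/kg and compound 1 `CCc1cccc2c(=O)c(-c3nn[nH]n3)c[nH]c12` gives 0.312 mg/kg. The step of a 2.0-fold lower number from compound 2 to compound 3 (0.30 log units; within the scatter) lies within the scatter, as does a 2.0-fold higher number from compound 1 to compound 3 (0.30 log units; within the scatter), whereas a 4.0-fold higher number from compound 1 to compound 2 (0.60 log units; beyond the scatter) lies beyond it. Compound 4 `O=c1c(-c2nn[nH]n2)c[nH]c2c(C(F)(F)F)cccc12` differs from compound 3 by trifluoromethyl in place of fluoro on an aromatic carbon. Within the data shown here, the steps that bear on this change are those at the same aromatic carbon: going from hydrogen through fluoro to ethyl, the number falls, and ethyl, like trifluoromethyl, brings more heavy atoms than fluoro. Compound 4 is therefore expected to give 0.4 mg/kg, within the range 0.15 mg/kg to 1.25 mg/kg, which would mean a 1.6-fold lower number from compound 3 to compound 4 (0.19 log units; within the scatter).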

Compound 4, minimum effective dose: 0.156 mg/kg
Compound 4: middle estimate off by 2.6-fold (0.41 log units), on the high side; the range from low to high includes it.
By their numbers in this assay, from the lowest: compounds 4, 1, 3 and 2 (each within the scatter of the next, the first and the last beyond it).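

In this assay the move to trifluoromethyl at this aromatic carbon gives a 4.0-fold lower number from compound 3 to compound 4 (0.60 log units; beyond the scatter) and, measured from the unsubstituted parent, an 8.0-fold lower number from compound 2 to compound 4 (0.90 log units; beyond the scatter) so this position accepts a group of four heavy atoms, and the fall now clearly exceeds the scatter, which the step from hydrogen to fluoro did not. Trifluoromethyl and ethyl cannot be told apart here, with a 2.0-fold lower number from compound 1 to compound 4 (0.30 log units; within the scatter) as their only comparison. From the compounds shown here alone, whether an amine, a carboxylic acid or a chain longer than ethyl would be tolerated at this carbon remains open. Nothing measured here explains the fall in the number with this change.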